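The source may report more compounds than this note shows. Statements on the series, on what has been measured and on what is new or still open speak of the compounds shown alone.

Compound 1, `CCCCCCCC/C=C\CCCCCCC(=O)c1ccccn1`, in an assay on isolated protein for inhibition of Fatty-acid amide hydrolase 1 (Homo sapiens) (a higher number here means a weaker inhibitor, a lower number a stronger inhibitor), gives > 100000 nM, which is a limit of the assay rather than a number.
Compound 2, `CCCCCCCC/C=C\CCCCCCC(=O)c1ccccc1`, gives > 100000 nM in this assay, again a limit.
Compound 3, `CCCCCCCC/C=C\CCCCCCC(=O)c1nc2ccc(C)cc2o1`, gives > 100000 nM in this assay, also a limit.

Compound 3 therefore stands where every measured compound stands: at the limit of > 100000 nM in this assay, at which 3 of the 3 values shown sit. Not one of the three has given an actual number in this assay. Among the compounds with values here, the single step between measured compounds, a step that the two limits leave unreadable from compound 1 to compound 2, cannot be sized, since both of its values are limits.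

Compound 4, `CCCCCCCC/C=C\CCCCCCC(=O)c1nc2ccccc2o1`, differs from compound 3 by hydrogen in place of methyl on an aromatic carbon, a hydrogen in place of methyl on an aromatic carbon. Within the data shown here, no measured step touches this part of the molecule, and the one step that exists, a step that the two limits leave unreadable from compound 1 to compound 2, is unreadable anyway. Among the measured compounds shown here, the only guide is that compound 3 itself sits at the limit, so compound 4 is expected to show no step beyond the scatter, a step that the limit leaves unreadable from compound 3 to compound 4, and most likely to be reported as a limit as well. The estimate for compound 4 in this assay is 200000 nM, within a range from 30000 nM to 1000000 nM.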

Compound 4, inhibition constant: 370 nM
For compound 4 the middle estimate is 540-fold (2.73 log units) above the measured one; measured number outside the range, below it.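

In this assay, this one aromatic carbon proves highly sensitive, even though the change is very small: hydrogen in place of methyl gives an at least 270-fold lower number from compound 3 to compound 4 (2.43 log units; beyond the scatter). The group on the carbonyl carbon matters as well, since 1,3-benzoxazol-2-yl in place of phenyl gives an at least 270-fold lower number from compound 2 to compound 4 (2.43 log units; beyond the scatter), and in place of pyridin-2-yl it gives an at least 270-fold lower number from compound 1 to compound 4 (2.43 log units; beyond the scatter). Each of these steps is only a minimum size, since one end of each is a limit of the assay and not a number: the limit of > 100000 nM in this assay, at which 3 of the 4 values shown sit.

Going by these compounds, what a chlorine or a methoxy group on this same carbon would give remains open, as does whether a methyl on another carbon of the six-membered ring would have the same effect. On these data alone, it is also open how far the result holds with a shorter chain on the carbonyl carbon.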